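The source may hold more compounds than are shown below. What is called first, only, known or untested is meant among the compounds shown, and "the series" means these compounds.

Of the compounds shown here, three built on one shared core have so far been measured in a functional assay on HeLa cells (Homo sapiens) for inhibition; on this read-out lower numbers stand for stronger inhibition and higher numbers for weaker inhibition. Compound 1 `Oc1ccc(-c2cc(-c3ccccc3C(F)(F)F)cc(-c3ccccc3O)n2)cc1` gives 16500 nM, compound 2 `Oc1cccc(-c2cc(-c3ccccc3OC(F)(F)F)cc(-c3ccccc3O)n2)c1` gives 15200 nM, and compound 3 `Oc1ccc(-c2cc(-c3ccccc3OC(F)(F)F)cc(-c3ccccc3O)n2)cc1` gives 6010 nM, the lowest of the three numbers; the steps of a 2.7-fold lower number from compound 1 to compound 3 (0.44 log units; beyond the scatter) and a 2.5-fold lower number from compound 2 to compound 3 (0.40 log units; beyond the scatter) both lie beyond the scatter, so compound 3 stands clearly apart from the other two. Compound 4 `Oc1ccc(-c2cc(-c3ccccc3OC(F)(F)F)cc(-c3cccc(O)c3)n2)cc1` has not yet been measured. It differs from compound 3 in a single place: 3-hydroxyphenyl in place of 2-hydroxyphenyl on an aromatic carbon. Among the compounds with values here, no measured step matches this change directly. The step of a 2.5-fold lower number from compound 2 to compound 3 (0.40 log units; beyond the scatter) exchanged a 3-hydroxyphenyl for a 4-hydroxyphenyl on the same core and gave a modest shift, which shows that relocating a hydroxyl on one of the phenyl groups can matter, but it does not settle the direction for the change now in hand. The step of a 2.7-fold lower number from compound 1 to compound 3 (0.44 log units; beyond the scatter) concerns a different group and does not bear on it. The expected step is therefore a 1.5-fold higher number from compound 3 to compound 4 (0.18 log units; within the scatter), small and of uncertain direction, leaning toward a somewhat higher number. The estimate for compound 4 in this assay is 9000 nM, with a range from 3000 nM to 27000 nM.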

Compound 4, half-maximal inhibitory concentration: 5800 nM
Estimate against measurement, compound 4: 1.6-fold (0.19 log units) above, and the stated range covers the measured number.
By their numbers in this assay, from the lowest: compounds 4 and 3 (each within the scatter of the next); then compounds 2 and 1 (each within the scatter of the next).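

In this assay, moving the hydroxyl from the 2-hydroxyphenyl to the 3-hydroxyphenyl form at this position, next to the ring nitrogen, gives a 1.0-fold lower number from compound 3 to compound 4 (0.02 log units; within the scatter). This position therefore accepts this change with no shift that can be told from the scatter, whereas the change from 3-hydroxyphenyl to 4-hydroxyphenyl on the other aryl group gave a 2.5-fold lower number from compound 2 to compound 3 (0.40 log units; beyond the scatter). The step of a 2.6-fold lower number from compound 2 to compound 4 (0.42 log units; beyond the scatter) shows that compound 4, with a 3-hydroxyphenyl group at the position studied here, stays as far from compound 2 as compound 3 does, so the lower number holds with either hydroxyphenyl form at this position. Nothing available explains this result.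

The compounds shown leave open whether this tolerance reaches beyond the two hydroxyphenyl forms, since only these two have been compared at this position. A 4-hydroxyphenyl group here, a plain phenyl without any hydroxyl, or a phenyl carrying a methoxy group, an amine or a carboxylic acid could each show whether the hydroxyl at this position contributes at all.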